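The source may report more compounds than this note shows. Statements on the series, on what has been measured and on what is new or still open speak of the compounds shown alone.

Measured so far in a functional assay on MKN-45 cells (Homo sapiens) for inhibition, with a stated time of 72 h (on this read-out higher numbers stand for weaker inhibition and lower numbers for stronger inhibition), are two compounds:

Compound 1 `COc1ccc(S(=O)(=O)N2CCc3cccc(-c4ccc(N)cc4)c32)cc1` gives 162 nM in this read-out
Compound 2 `COc1ccc(S(=O)(=O)N2CCc3cccc(-c4cccc(F)c4)c32)cc1` gives 84.7 nM in this read-out

Compound 2 stands within the scatter of compound 1, so the two cannot be ranked. Compound 3 `COc1ccc(S(=O)(=O)N2CCc3cccc(-c4cccs4)c32)cc1` has not yet been measured. It carries thiophen-2-yl in place of 3-fluorophenyl on an aromatic carbon of the shared core. Going by the values given here, the one measured step that bears on this change is a 1.9-fold lower number from compound 1 to compound 2 (0.28 log units; within the scatter) with 3-fluorophenyl in place of 4-aminophenyl on an aromatic carbon, and it stays within the scatter. Among the compounds with values here, no measured compound carries thiophen-2-yl, so this evidence is indirect. A change beyond the scatter is therefore not expected in this assay and no direction is favoured. The estimate amounts to an expected 1.2-fold higher number from compound 2 to compound 3 (0.07 log units; within the scatter) at most in size. For compound 3 the estimated value is (100 nM) with an expected range (40 nM to 250 nM).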

Compound 3, half-maximal inhibitory concentration: 165 nM
The estimate for compound 3 lay 1.7-fold (0.22 log units) below the measured number; the measured number falls inside the stated range.
By their numbers in this assay, from the lowest: compounds 2, 1 and 3 (each within the scatter of the next).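

In this assay, thiophen-2-yl on this aromatic carbon of the shared core stands within the scatter of both phenyl groups, with a 1.9-fold higher number from compound 2 to compound 3 (0.29 log units; within the scatter) and a 1.0-fold higher number from compound 1 to compound 3 (0.01 log units; within the scatter). The position therefore accepts a five-membered aromatic ring with one hetero atom, as well as 3-fluorophenyl and 4-aminophenyl, with no ranking possible among the three compounds, something the two six-membered rings alone could not show. Nothing available here explains why these three groups give numbers that cannot be told apart.

All three groups are aromatic rings, so the compounds shown leave open whether a carboxylic acid, a morpholine or a plain alkyl chain on this carbon would stay within the same scatter. They also leave open how replacing the methoxy group would read in this assay.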